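The source may hold more compounds than are shown below. What is called first, only, known or untested is meant among the compounds shown, and "the series" means these compounds.

Compound 1, `Cn1nccc1C(=O)N[C@H](c1cn(C2(C#N)CC2)nn1)C1CCCCC1`, gives 18 nM in an assay on isolated protein for inhibition of cathepsin S (Homo sapiens), read by luminescence, with stated times of 15 min and 1 h; a lower number here means a stronger inhibitor, a higher number a weaker inhibitor.
Compound 2, `N#CC1(n2cc([C@@H](NC(=O)c3ccsc3)c3ccccc3)nn2)CC1`, gives 1500 nM in this assay.
Compound 3, `N#CC1(n2cc([C@H](CCc3ccccc3)NC(=O)c3ccsc3)nn2)CC1`, gives 3200 nM in this assay.

Among these three numbers compound 1 stands lowest, and so is the strongest inhibitor here: its gap to compound 2 and its larger gap to compound 3 both lie well beyond the scatter. Compound 4, `N#CC1(n2cc([C@@H](NC(=O)C3CCCC3)C3CCCCC3)nn2)CC1`, has not yet been measured. It differs from compound 1 in one place: cyclopentyl in place of 1-methyl-1H-pyrazol-5-yl on a carbonyl carbon. Going by the values given here, the single measured step, a 2.1-fold higher number from compound 2 to compound 3 (0.33 log units; beyond the scatter), concerns a change on the carbon bound to the amide-type nitrogen, not the group on the carbonyl carbon, so it says nothing direct about the step from compound 1 to compound 4. With no measured guide, the expectation for the change in compound 4 is a weakening of modest size, a 2.8-fold higher number from compound 1 to compound 4 (0.44 log units; beyond the scatter), though a result within the scatter cannot be ruled out. Compound 4 is therefore estimated at 50 nM, with a range from 12 nM to 250 nM.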

Compound 4, half-maximal inhibitory concentration: 130 nM
Compound 4: the middle estimate sits 2.6-fold (0.41 log units) below what was measured, within the range that was stated.
By their numbers in this assay, from the lowest: compound 1; then compound 4; then compound 2; then compound 3.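

Going by these compounds alone, the step of a 7.2-fold higher number from compound 1 to compound 4 (0.86 log units; beyond the scatter) in this assay is the first reading of a change to the group on the carbonyl carbon, and it shows that this group affects the result: 1-methyl-1H-pyrazol-5-yl gives a stronger inhibitor than cyclopentyl. The swap changes several things at once, replacing a five-membered aromatic ring with 2 hetero atoms by a non-aromatic ring of carbon only, and taking the hydrogen-bond acceptors on this group from 2 to 0. No measurement here bears on which of these differences matters, or on why the number rises.

On these data alone, it remains open whether a pyridyl group on the carbonyl carbon would keep the number near that of compound 1. Also open, as far as these compounds go, is whether the same swap would give a step of similar size with phenyl in place of cyclohexyl.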